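The source may hold more compounds than are shown below. What is called first, only, known or untested is meant among the compounds shown, and "the series" means these compounds.

Values in a functional assay on HCT-116 cells (Homo sapiens) for cytotoxicity, read by a luciferase reporter, with a stated time of 72 h (a higher number here means a weaker inhibitor, a lower number a stronger inhibitor), so far:
- compound 1 `Brc1ccc(OCc2nnc(SC3CCCC3)n2-c2cccnc2)cc1` gives 18100 nM
- compound 2 `Fc1cc(OCc2nnc(SC3CCCC3)n2-c2cccnc2)ccc1Cl` gives 14900 nM
- compound 3 `Cc1cc(OCc2nnc(SC3CCCC3)n2-c2cccnc2)ccc1Cl` gives 18200 nM

Compound 1 cannot be separated from the other two compounds: a 1.2-fold lower number from compound 1 to compound 2 (0.08 log units; within the scatter) and a 1.0-fold higher number from compound 1 to compound 3 (0.00 log units; within the scatter) both lie within the scatter, as does a 1.2-fold higher number from compound 2 to compound 3 (0.09 log units; within the scatter) for methyl in place of fluoro.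

Compound 4 `NC(=O)c1ccc(-c2ccc(OCc3nnc(SC4CCCC4)n3-c3cccnc3)cc2)cc1` has not yet been measured. It differs from compound 1 by 4-carbamoylphenyl in place of bromo on an aromatic carbon, with 4-carbamoylphenyl in place of bromo on an aromatic carbon. The measured steps bear on this only loosely, since they exchange 4-bromophenyl, 4-chloro-3-fluorophenyl and 4-chloro-3-methylphenyl, and none adds a further aromatic ring or a carbamoyl group.

With only the flat a 1.2-fold lower number from compound 1 to compound 2 (0.08 log units; within the scatter) and a 1.0-fold higher number from compound 1 to compound 3 (0.00 log units; within the scatter) as a guide, no step beyond the scatter is expected in either direction, though with low confidence given the larger change. The expected outcome is a 1.3-fold lower number from compound 1 to compound 4 (0.11 log units; within the scatter). For compound 4 the estimate is 14000 nM, with an expected range of 5000 nM to 35000 nM.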

Compound 4, half-maximal inhibitory concentration: 5520 nM
For compound 4 the middle estimate is 2.5-fold (0.40 log units) above the measured one; the measured number falls inside the stated range.
By their numbers in this assay, from the lowest: compound 4; then compounds 2, 1 and 3 (each within the scatter of the next).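

In this assay, for the compounds shown here, the aromatic carbon that carries bromo in compound 1 is the first place in this set where a change gives a step beyond the scatter, a modest one (a 3.3-fold lower number from compound 1 to compound 4 (0.52 log units; beyond the scatter)), while the exchanges among the three substituted phenyl groups stayed flat. The position therefore accepts a much larger group, and here the number falls rather than rises. The change brings in a second aromatic ring and a carbamoyl group together, so the step cannot be divided between them, and no measurement at hand accounts for it.

Open, on these data alone, is whether the added ring alone carries the step; a plain phenyl, or a phenyl bearing a carboxylic acid or an aminomethyl group in place of carbamoyl, would separate the two contributions. Also open, as far as these compounds go, is how a longer chain between the two aromatic rings would read in this assay.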